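The source may hold more compounds than are shown below. What is called first, only, known or untested is meant among the compounds shown, and "the series" means these compounds.

Of the compounds shown here, three have been measured so far in an in vitro ADME assay on microsomes from liver (Rattus norvegicus) for metabolic stability (on this read-out higher numbers stand for a longer-lived compound and lower numbers for a shorter-lived compound), and they give a narrow picture. Compound 1 (`CNc1nc(NCc2ccc(NC(=O)c3ccc(C#N)cc3)cc2)c2ccccc2n1`) gives 0.167 h and compound 2 (`CN(C)c1nc(NCc2ccc(NC(=O)c3ccc(F)cc3)cc2)c2ccc(C#N)cc2n1`) gives 0.183 h and these two numbers lie within the scatter of each other. Compound 3 (`CN(C)c1nc(NCc2ccc(NC(=O)c3ccc(F)cc3)cc2)c2ccc(C=O)cc2n1`) gives 0.05 h as the lowest of the three numbers, beyond the scatter from both of the others. Among the compounds with values here, the only step between measured compounds that differ in one place is a 3.7-fold lower number from compound 2 to compound 3 (0.56 log units; beyond the scatter) with formyl in place of cyano on an aromatic carbon. Compound 4 (`CN(C)Cc1ccc2c(NCc3ccc(NC(=O)c4ccc(F)cc4)cc3)nc(N(C)C)nc2c1`) differs from compound 3 in one place, with (dimethylamino)methyl in place of formyl on an aromatic carbon. Within the data shown here, no measured compound carries (dimethylamino)methyl, so no step speaks to this change directly. Compound 2 carries no formyl and stands at 0.183 h so a rise is expected when formyl leaves, though the entering group is not cyano and the rise may fall short of the measured step. The expected step in this assay is therefore a 2.4-fold higher number from compound 3 to compound 4 (0.38 log units; beyond the scatter) as an uncertain estimate. For compound 4 the expected value is 0.12 h within an estimated range of 0.05 h to 0.3 h in this measurement.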

Compound 4, half-life: 0.05 h
Compound 4: the middle estimate sits 2.4-fold (0.38 log units) above what was measured; the measured number falls inside the stated range.
By their numbers in this assay, from the lowest: compounds 3 and 4 (each within the scatter of the next); then compounds 1 and 2 (each within the scatter of the next).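

In this assay, replacing formyl with (dimethylamino)methyl on this aromatic carbon gave no change at the digits printed from compound 3 to compound 4 (within the scatter), so the short half-life seen with formyl is not confined to that group. Set against the nitrile, (dimethylamino)methyl gave a 3.7-fold lower number from compound 2 to compound 4 (0.56 log units; beyond the scatter), which means that two quite different groups at this position now stand apart from the nitrile, where earlier only formyl did. Nothing measured in hand accounts for either step.

The compounds shown leave open whether the higher number belongs to the nitrile alone or would also appear with other groups on this carbon, such as a carboxylic acid, a primary amide or a methoxy group. They also leave open whether the result for (dimethylamino)methyl would hold for a cyclic amine such as morpholine or for a longer chain ending in the same amine, and whether any such change would read the same on the other parts of the shared core.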